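Swapping a bromine for a benzyloxy group on a chalcone

The compounds below may be only part of what the source reports. "The series", "measured", "known", "first", "only" and "open" are said of these compounds alone.

The compounds here share the core of compound 1, `COc1ccc(/C=C/C(=O)c2ccc(O)cc2O)c(OC)c1`, a chalcone whose one ring carries two hydroxyl groups. In a functional assay on NCI-H460 cells (Homo sapiens) for inhibition, read by sulforhodamine B assay, with a stated time of 48 h (on this read-out lower numbers stand for stronger inhibition of growth and higher numbers for weaker inhibition of growth), compound 1 gives 37000 nM, a weak result. Compound 2, `O=C(/C=C/c1ccc(Br)cc1)c1ccc(O)cc1O`, carries a bromo group on the other ring instead of the two methoxy groups of compound 1; for compound 2 the outcome in this assay is "not determined" (no result reported), so no number is available to place it against compound 1. Compound 3, `O=C(/C=C/c1ccc(OCc2ccccc2)cc1)c1ccc(O)cc1O`, is the next step: benzyloxy in place of bromo on an aromatic carbon, a benzyloxy in place of bromo on an aromatic carbon. Within the data shown here, with no measured step for this pair, the expectation rests only on the weak result of compound 1, and the change is expected to move the number little, perhaps in either direction, staying within the usual scatter. Compound 3 is therefore estimated to reach about 25000 nM in this assay, with the likely span running from 7000 nM to 80000 nM.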

Compound 3, concentration for 50% growth inhibition: 10500 nM
The estimate for compound 3 lay 2.4-fold (0.38 log units) above the measured number; low and high end bracket the measured number.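

In this assay compound 3 gives 10500 nM but compound 2 has no number to set beside it, so no step can be read for the swap of bromo for benzyloxy. The compounds shown leave open how either group on that ring affects growth inhibition. No measured finding here explains the value of compound 3.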